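The source may report more compounds than this note shows. Statements on the series, on what has been measured and on what is new or still open speak of the compounds shown alone.

Among the compounds with values here, in a functional assay on MCF7 cells (Homo sapiens) for cytotoxicity, read by MTT assay, with a stated time of 48 h (on this read-out higher numbers stand for weaker inhibition and lower numbers for stronger inhibition), three compounds have numbers so far. Compound 1 `C/C(=N/NC(=S)Nc1ccccc1F)c1ccccn1` gives 0.39 nM, compound 2 `CC(=NNC(=S)Nc1ccccc1[N+](=O)[O-])c1ccccn1` gives 5.7 nM, and compound 3 `C/C(=N/NC(=S)Nc1ccccc1I)c1ccccn1` gives 4.1 nM. Compound 3 therefore lies within the scatter of compound 2, while the measured path from the first compound is an 11-fold higher number from compound 1 to compound 3 (1.02 log units; beyond the scatter), a large step beyond the scatter, with iodo in place of fluoro on an aromatic carbon.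

The next compound, compound 4 `C/C(=N/NC(=S)Nc1ccccc1[N+](=O)[O-])c1ccccn1`, has not yet been measured. It differs from compound 3 as follows: nitro in place of iodo on an aromatic carbon. In words, this is nitro in place of iodo on an aromatic carbon, ortho to a large group. Within the data shown here, the one measured step shows that a change of group on an aromatic carbon can move the number well beyond the scatter, but it involves no nitro group. Closer evidence comes from compound 2, which is drawn with the same groups as compound 4 but leaves the geometry at the double bond open. Compound 2 gives 5.7 nM. No step beyond the scatter is therefore expected in this assay. The expected change is small, estimated as a 1.2-fold higher number from compound 3 to compound 4 (0.09 log units; within the scatter). For compound 4 the estimated value is 5 nM, with an expected range of 2.2 nM to 11 nM.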

Compound 4, half-maximal inhibitory concentration: 5.7 nM
Beside the measured number, compound 4's estimate is 1.1-fold (0.06 log units) below it; measured number inside the range.
By their numbers in this assay, from the lowest: compound 1; then compounds 3, 2 and 4 (each within the scatter of the next).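

In this assay, nitro and iodo at this place, on an aromatic carbon ortho to a large group, cannot be told apart, with a 1.4-fold higher number from compound 3 to compound 4 (0.14 log units; within the scatter). The earlier compounds showed a large step only for iodo replacing fluoro, and nitro now gives a large step of its own, with a 15-fold higher number from compound 1 to compound 4 (1.16 log units; beyond the scatter), so among these three groups fluoro is the one that stands apart. Drawing the double bond with or without a configuration adds no separate difference here, with no change at the digits printed from compound 2 to compound 4 (within the scatter), and the only difference on record for that pair is this: the fact that one of compounds 2 and 4 is drawn with a defined configuration and the other without, at the place where they differ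

The compounds shown leave open whether an amine, a methoxy group, a chloro group or plain hydrogen at this place would fall with fluoro or with iodo and nitro, and so whether the low number of compound 1 is particular to fluoro. They also leave open how any of these groups would read on another carbon of the same ring, and what lies behind the gap between fluoro and the other two groups.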